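From Allyl to Isopropyl on the Ring Amine

The compounds below may be only part of what the source reports. "The series", "measured", "known", "first", "only" and "open" are said of these compounds alone.

Of the compounds shown here, three sharing one core have been measured. In an assay on isolated protein for inhibition of Amine oxidase [flavin-containing] A (Homo sapiens), read by fluorescence and Amplex Red, with a stated time of 30 min, tested at 100 uM (on this read-out higher numbers stand for a stronger effect at the one concentration tested and lower numbers for a weaker effect), compound 1 `CCCNc1nnc(SCC(=O)N(Cc2cccc([N+](=O)[O-])c2)c2ccc(F)cc2)s1` gives 91.1%, compound 2 `COCCNc1nnc(SCC(=O)N(Cc2cccc([N+](=O)[O-])c2)c2ccc(F)cc2)s1` gives 91.6%, and compound 3 `C=CCNc1nnc(SCC(=O)N(Cc2cccc([N+](=O)[O-])c2)c2ccc(F)cc2)s1` gives 86.4%. Compound 3 sits at the bottom of these three numbers, yet only within the scatter: a number 4.7 percentage points lower from compound 1 to compound 3 (within the scatter) and a number 5.2 percentage points lower from compound 2 to compound 3 (within the scatter). Compound 4 `CC(C)Nc1nnc(SCC(=O)N(Cc2cccc([N+](=O)[O-])c2)c2ccc(F)cc2)s1` differs from compound 3 by isopropyl in place of allyl on a nitrogen on an aromatic ring. The two measured steps are the ones that bear on this, since each also exchanged one short chain for another at that same nitrogen, and neither moved beyond the scatter. No step beyond the scatter is therefore expected in this assay: a number 2.6 percentage points higher from compound 3 to compound 4 (within the scatter). Compound 4 is estimated at 89%, expected between 80% and 95%.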

Compound 4, a percentage reported as inhibition, at one concentration (the size of the read-out at that concentration, not a potency): 89.1%
Beside the measured number, compound 4's estimate is 0.1 percentage points below it, and the stated range covers the measured number.
By their numbers in this assay, from the lowest: compounds 3, 4, 1 and 2 (each within the scatter of the next).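

A branched chain on the nitrogen on an aromatic ring is new here, and in this assay putting isopropyl in place of propyl gives a number 2 percentage points lower from compound 1 to compound 4 (within the scatter) and no readable change. The comparisons with allyl and 2-methoxyethyl give a number 2.7 percentage points higher from compound 3 to compound 4 (within the scatter) and a number 2.5 percentage points lower from compound 2 to compound 4 (within the scatter) and these four chains cannot be told apart at this one concentration. No evidence is available to explain this result. Still open, on these data alone, is whether a larger group at this nitrogen, such as a benzyl or a cyclohexyl, or a charged one such as a carboxylic acid on the chain, would move the number beyond the scatter.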